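Replacing a methyl ketone with an aryl ketone

A few compounds are considered here, and "the series" means these few. Any claim that something is new, unique, unknown or untested is made for them only; others in the source may bear on it.

Compound 1 `COc1cc(-c2cc(/C=C/C(C)=O)[nH]n2)cc(OC)c1OC` is the weaker of the two measured compounds: in a functional assay on MDA-MB-231 cells (Homo sapiens) for inhibition, read by MTT assay, with a stated time of 48 h (a higher number here means a weaker inhibitor, a lower number a stronger inhibitor), compound 1 gives 27300 nM, whereas compound 2 `COc1ccc2c(c1)C/C(=C\c1cc(-c3cc(OC)c(OC)c(OC)c3)n[nH]1)C2=O` gives 2000 nM, a gap beyond the scatter. Compound 3 `COc1cc(-c2cc(/C=C/C(=O)c3ccc(Cl)cc3)[nH]n2)cc(OC)c1OC` has not yet been measured. It differs from compound 1 by 4-chlorophenyl in place of methyl on a carbonyl carbon. Because compound 2 gives 2000 nM while carrying a larger carbonyl partner, a step toward stronger inhibition is expected, and the estimated step of a 5.5-fold lower number from compound 1 to compound 3 (0.74 log units; beyond the scatter) is beyond the scatter. For compound 3 the expected value is 5000 nM, within a range from 1500 nM to 16000 nM.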

Compound 3, half-maximal inhibitory concentration: 26000 nM
Beside the measured number, compound 3's estimate is 5.2-fold (0.72 log units) below it, outside the stated range (above it).
By their numbers in this assay, from the lowest: compound 2; then compounds 3 and 1 (each within the scatter of the next).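

In this assay, putting 4-chlorophenyl in place of methyl on a carbonyl carbon gives a 1.1-fold lower number from compound 1 to compound 3 (0.02 log units; within the scatter), so the two compounds cannot be told apart. At this carbon, then, a group of 7 heavy atoms with an aromatic ring reads the same as a methyl of 1 heavy atom, and adding this ring alone brings no measurable gain. Nothing measured here gives a reason for this result. Still open, from the compounds shown here alone, is whether a plain phenyl, or a phenyl carrying an amine or a carboxylic acid in place of chlorine, would shift the number.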